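Phenyl in Place of Cyclopropyl on the Aromatic Nitrogen

The source may report more compounds than this note shows. Statements on the series, on what has been measured and on what is new or still open speak of the compounds shown alone.

Measured compounds:
compound 1 `COc1ccc([N+](=O)[O-])cc1CSc1nc2cc(NC(=O)NC(C)(C)C)ccc2n1C1CC1`: 860 nM
compound 2 `COc1ccc([N+](=O)[O-])cc1CSc1nc2cc(NC(=O)NC(C)(C)C)ccc2n1Cc1cccnc1`: 150 nM

In an assay on isolated protein for inhibition of Gonadotropin-releasing hormone receptor (Rattus norvegicus) (on this read-out lower numbers stand for stronger inhibition and higher numbers for weaker inhibition), compound 1 gives 860 nM, the higher of the two numbers. Compound 2 gives 150 nM in this assay. Among the measured compounds shown here, the single measured step, a 5.7-fold lower number from compound 1 to compound 2 (0.76 log units; beyond the scatter), comes from replacing the cyclopropyl on the aromatic nitrogen with a larger group carrying an aromatic ring.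

Compound 3 `COc1ccc([N+](=O)[O-])cc1CSc1nc2cc(NC(=O)NC(C)(C)C)ccc2n1-c1ccccc1` differs from compound 1 by phenyl in place of cyclopropyl on an aromatic nitrogen. This change also replaces the cyclopropyl with an aromatic ring on the same nitrogen, though here the ring is attached directly and carries no nitrogen. The step from compound 1 to compound 2 is the only one that bears on it, and it suggests that a larger group at this position is tolerated. Compound 3 is therefore expected to lie below compound 1 in this assay, with an estimated step of a 2.5-fold lower number from compound 1 to compound 3 (0.39 log units; beyond the scatter). The estimate for compound 3 is 350 nM, within a range of 100 nM to 1200 nM.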

Compound 3, half-maximal inhibitory concentration: > 2600 nM
Compound 3: only a limit was reported; the forecaster's own chance of this, stated with the estimate: 5%; at least 7.4-fold (0.87 log units) between middle value and limit.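

Compound 3 is recorded only as a limit of the assay in this assay: the limit of > 2600 nM in this assay, at which 1 of the 3 values shown sits. Even as a limit it gives two readable steps, an at least 3.0-fold higher number from compound 1 to compound 3 (0.48 log units; beyond the scatter) and an at least 17-fold higher number from compound 2 to compound 3 (1.23 log units; beyond the scatter). An aromatic ring on this nitrogen therefore does not by itself give a lower number, and neither does a larger group, since phenyl and (pyridin-3-yl)methyl go in opposite directions from cyclopropyl.

Compound 2 differs from compound 3 in both the ring nitrogen and the methylene link, so the compounds shown cannot say which of the two carries the difference, a question that benzyl or a directly attached pyridin-3-yl on the same nitrogen would address. From the compounds shown here alone, how far the true value of compound 3 lies beyond its limit also remains open.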